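The source may hold more compounds than are shown below. What is called first, only, known or untested is meant among the compounds shown, and "the series" means these compounds.

In a functional assay on HCT-116 cells (Homo sapiens) for antiproliferative activity, read by MTT assay, with a stated time of 72 h (on this read-out higher numbers stand for weaker inhibition and lower numbers for stronger inhibition), compound 3 `NC1=NC2(CCOCC2)N(OCCCOc2cccc(Br)c2)C(N)=N1` gives 40 nM and sits level with compound 1 `NC1=NC2(CCOCC2)N(OCCCOc2ccccc2Cl)C(N)=N1` at 70 nM since the data show a 1.8-fold lower number from compound 1 to compound 3 (0.24 log units; within the scatter) for this pair. Compound 2 `NC1=NC2(CCOCC2)N(OCCCOc2ccc(F)cc2)C(N)=N1` at 3280 nM lies far from both, with a 47-fold higher number from compound 1 to compound 2 (1.67 log units; beyond the scatter) and an 82-fold lower number from compound 2 to compound 3 (1.91 log units; beyond the scatter) as the large steps. Those two steps both run through compound 2 and say little about the next change.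

The move to compound 4 `NC1=NC2(CCOCC2)N(OCCCOc2cccc(Cl)c2)C(N)=N1` is chloro in place of bromo on an aromatic carbon in the form of chloro in place of bromo on an aromatic carbon, meta to a large group. Among the measured compounds shown here, no measured pair isolates this exchange. The closest evidence is compound 1, which also carries a chloro group and still gives 70 nM in this assay on the same core. No step beyond the scatter is therefore expected, and no clear direction. The estimate is a 1.3-fold higher number from compound 3 to compound 4 (0.10 log units; within the scatter) as the expected size of the change. For compound 4 the estimated value is 50 nM with an expected range from 20 nM to 130 nM in this series.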

Compound 4, half-maximal inhibitory concentration: 120 nM
Beside the measured number, compound 4's estimate is 2.4-fold (0.38 log units) below it; low and high end bracket the measured number.
By their numbers in this assay, from the lowest: compounds 3, 1 and 4 (each within the scatter of the next, the first and the last beyond it); then compound 2.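

In this assay, among the compounds shown here, chloro in place of bromo, meta to a large group, gives a 3.0-fold higher number from compound 3 to compound 4 (0.48 log units; beyond the scatter) and is a modest step beyond the scatter, so the halogen itself registers at this position, which no earlier pair could show. With chloro kept on the ring, 3-chlorophenyl in place of 2-chlorophenyl gives a 1.7-fold higher number from compound 1 to compound 4 (0.23 log units; within the scatter) and does not separate the two, while 3-chlorophenyl in place of 4-fluorophenyl gives a 27-fold lower number from compound 2 to compound 4 (1.44 log units; beyond the scatter) and leaves compound 2 clearly apart from compound 4. Nothing measured here bears on what lies behind these steps.

Still open, as far as these compounds go, is whether the gap to compound 2 follows the fluoro group or its place, which a fluoro group at the place of the chloro in compound 4 would test. From the compounds shown here alone, how a methoxy group or an amine at that place compares with the halogens also remains open.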